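This account rests on a few compounds, and the source may have more. Where it says the series, first, only, none or still open, it means among the compounds named here.

Compound 1 `COc1cccc(/C=C/C(=O)c2c(OC)cc(OC)c(CC=C(C)C)c2O)c1`: 49200 nM
Compound 2 `COc1cc(OC)c(C(=O)/C=C/c2ccc(C(F)(F)F)cc2)c(O)c1CC=C(C)C`: 73700 nM

Going by the values given here, these two values come from an ADME assay on MCF7-DOX cells (Homo sapiens) for cytotoxicity, read by MTT assay, with a stated time of 48 h (a lower number here means a stronger inhibitor, a higher number a weaker inhibitor), and compound 1 stands level with compound 2, the only other compound measured, as the one step between them shows: a 1.5-fold higher number from compound 1 to compound 2 (0.18 log units; within the scatter). Compound 3 `COc1cc(OC)c(C(=O)/C=C/c2cccc(N3CCNCC3)c2)c(O)c1CC=C(C)C` changes compound 1 in one place: piperazin-1-yl in place of methoxy on an aromatic carbon. Piperazin-1-yl replaces methoxy on an aromatic carbon. Among the compounds with values here, that single measured step is the only guide, and no measured compound carries piperazin-1-yl, so no change beyond the scatter is firmly expected. The expected change is a 1.6-fold lower number from compound 1 to compound 3 (0.21 log units; within the scatter). Compound 3 is estimated at 30000 nM, with a range from 8000 nM to 75000 nM.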

Compound 3, half-maximal inhibitory concentration: 99900 nM
Compound 3: the middle estimate sits 3.3-fold (0.52 log units) below what was measured; the measured number lies above the stated range.
By their numbers in this assay, from the lowest: compounds 1, 2 and 3 (each within the scatter of the next, the first and the last beyond it).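

In this assay the swap of methoxy for piperazin-1-yl on this aromatic carbon brings a 2.0-fold higher number from compound 1 to compound 3 (0.31 log units; beyond the scatter) as a modest weakening, so this larger ring with its hydrogen-bond donor gives no gain over methoxy here. Unlike the earlier step, this single change goes beyond the scatter. Nothing available explains the step. Still open, as far as these compounds go, is whether a plain amino group or morpholin-4-yl on this carbon would match methoxy. Also open, from the compounds shown here alone, is whether piperazin-1-yl would behave the same elsewhere on this ring.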